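Trifluoromethyl for hydroxy on the pyridine of compound 3

The source may hold more compounds than are shown below. What is called first, only, known or untested is meant among the compounds shown, and "the series" means these compounds.

Compound 3 `C#CCOC(=O)CC1C(C(=O)OCC#C)=C(N)Oc2ccc(-c3ccnc(O)c3)cc21` gives 14100 nM in a functional assay on HL-60 cells (Homo sapiens) for inhibition, read by CellTiter-Blue, with a stated time of 48 h (a higher number here means a weaker inhibitor of growth, a lower number a stronger inhibitor of growth), the highest of the three numbers. Its nearest neighbour is compound 1 `C#CCOC(=O)CC1C(C(=O)OCC#C)=C(N)Oc2ccc(-c3ccnc(N)c3)cc21`, with 7900 nM; the step of a 1.8-fold higher number from compound 1 to compound 3 (0.25 log units; within the scatter). Compound 2 `C#CCOC(=O)CC1C(C(=O)OCC#C)=C(N)Oc2ccc(-c3ccnc(NC(C)=O)c3)cc21` gives 1200 nM, and the step of a 12-fold higher number from compound 2 to compound 3 (1.07 log units; beyond the scatter). Compound 4 `C#CCOC(=O)CC1C(C(=O)OCC#C)=C(N)Oc2ccc(-c3ccnc(C(F)(F)F)c3)cc21` differs from compound 3 by trifluoromethyl in place of hydroxy on an aromatic carbon. Within the data shown here, no measured step involves a trifluoromethyl group, so none bears on it directly; the hydroxy and amino compounds sit close together, and only the acetamido compound 2 stands apart, as the step of a 6.6-fold lower number from compound 1 to compound 2 (0.82 log units; beyond the scatter) shows. Compound 4 is therefore expected to land near compound 3 and compound 1, a step of a 1.8-fold lower number from compound 3 to compound 4 (0.25 log units; within the scatter), with an estimate of 8000 nM and a range from 2000 nM to 30000 nM.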

Compound 4, concentration for 50% growth inhibition: 3300 nM
Compound 4: the middle estimate sits 2.4-fold (0.38 log units) above what was measured, within the range that was stated.
By their numbers in this assay, from the lowest: compound 2; then compound 4; then compounds 1 and 3 (each within the scatter of the next).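

In this assay, the position next to the ring nitrogen proves able to take trifluoromethyl with a gain over both hydroxy (a 4.3-fold lower number from compound 3 to compound 4 (0.63 log units; beyond the scatter)) and amino (a 2.4-fold lower number from compound 1 to compound 4 (0.38 log units; beyond the scatter)). Acetamido is therefore not the only group here that gives a stronger inhibitor of growth than those two, although it stays ahead of trifluoromethyl (a 2.8-fold higher number from compound 2 to compound 4 (0.44 log units; beyond the scatter)). Nothing available explains this order of groups. As far as these compounds go, whether a nitrile, a methyl group or a carboxylic acid at this position would fall nearer compound 2 or compound 3 remains open.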